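A few compounds are considered here, and "the series" means these few. Any claim that something is new, unique, unknown or untested is made for them only; others in the source may bear on it.

Of the compounds shown here, three have been tested for cytotoxicity in an ADME assay on HepG2 cells (Homo sapiens) for cytotoxicity, with a stated time of 72 h (on this read-out lower numbers stand for an effect already at smaller amounts and higher numbers for an effect only at larger amounts of compound), and none of them gave a measurable number. Compound 1 `Cc1ccc(-c2nc3ccccc3s2)cc1NC(=O)c1cc([N+](=O)[O-])c(N2CCCCC2)cc1Cl` reached only the limit of this assay, recorded as > 25000 nM. Compound 2 `O=C(Nc1ccccc1-c1nc2ccccc2s1)c1cc([N+](=O)[O-])ccc1Cl` likewise stopped at a limit of this assay, given as > 27000 nM. Compound 3 `O=C(Nc1cccc(-c2ccccc2)c1)c1cc([N+](=O)[O-])ccc1Cl` also stopped at a limit of this assay, given as > 27000 nM. Among the compounds with values here, compound 1 thus sits at the limit of > 25000 nM in this assay, at which 1 of the 3 values shown sits, while the two others sit at the limit of > 27000 nM in this assay, at which 2 of the 3 values shown sit; since every value is a limit, no compound can be set above or below another on this read-out.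

The unmeasured compound 4 `Cc1ccc(-c2nc3ccccc3s2)cc1NC(=O)c1cc([N+](=O)[O-])ccc1Cl` differs from compound 1 in one place: hydrogen in place of piperidin-1-yl on an aromatic carbon. Within the data shown here, no pair of measured compounds differs in a single place, so no measured step gives a scale for this change. Within these three results the limits leave no room for any direction to show itself, and the expectation for this step is none beyond the scatter. The step that the limit leaves unreadable from compound 1 to compound 4 is therefore estimated to be flat. Compound 4 is expected to give 30000 nM in this assay, with a range from 15000 nM to 60000 nM, and most probably only a limit will again be reported.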

Compound 4, half-maximal effective concentration: > 14000 nM
Compound 4 was reported as a limit (the forecaster's own chance of this, stated with the estimate: 85%); the middle value lies beyond the limit too.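

Compound 1 and compound 4 are both recorded only as limits in this assay, so the exchange of piperidin-1-yl for hydrogen on the aromatic carbon cannot be read as a step of any size. The compounds shown leave open whether any of the four reaches a measurable value on this read-out, and whether that exchange changes it at all.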